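The compounds below may be only part of what the source reports. "The series", "measured", "known", "first", "only" and "open" are said of these compounds alone.

The study sets compound 1 `CCCCCCc1ccc(-c2ccc(C(=O)N3CCC[C@H]3C(=O)N[C@H](C(=O)N[C@@H](C)C(=O)N[C@@H](CC(N)=O)C(=O)N[C@@H](C)B3O[C@@H]4C[C@@H]5C[C@@H](C5(C)C)[C@]4(C)O3)[C@H](C)O)cc2)cc1` beside compound 2 `CCCCCCc1ccc(-c2ccc(C(=O)N3CCC[C@H]3C(=O)N[C@H](C(=O)N[C@@H](C)C(=O)N[C@@H](CC(N)=O)C(=O)N[C@@H](C)B(O)O)[C@H](C)O)cc2)cc1`, two close relatives built on the same core. In a toxicity assay on HepG2 cells (Homo sapiens) for cytotoxicity, read by fluorescence, with a stated time of 72 h (a lower number here means a stronger inhibitor, a higher number a weaker inhibitor), compound 1 gives 4700 nM. For compound 2 the result in this assay is only a limit of the assay, > 64000 nM, so compound 2 stands at the weak end of the numbers shown, sitting at the limit of > 64000 nM in this assay, at which 1 of the 2 values shown sits. Compound 3 `CCCCCCc1ccc(-c2ccc(C(=O)N3CC(CN)C[C@H]3C(=O)N[C@H](C(=O)N[C@@H](C)C(=O)N[C@@H](CC(N)=O)C(=O)N[C@@H](C)B(O)O)[C@H](C)O)cc2)cc1` is derived from compound 2 by a single change: aminomethyl in place of hydrogen on a saturated ring carbon. Among the compounds with values here, no step between measured compounds bears on this change, so the expectation for the step of a number no higher from compound 2 to compound 3 (the limit leaves the size open) is one that stays within the scatter of repeated measurements, with no clear direction. Compound 3 is therefore expected to give about 64000 nM in this assay, within a range from 16000 nM to 250000 nM, and it may well again be reported only as a limit.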

Compound 3, half-maximal inhibitory concentration: 15600 nM
Compound 3: middle estimate off by 4.1-fold (0.61 log units), on the high side, and the stated range ends above it.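

Aminomethyl in place of hydrogen on a saturated ring carbon, two ring bonds from the ring nitrogen, does not leave the reading in this assay unchanged: it gives an at least 4.1-fold lower number from compound 2 to compound 3 (0.61 log units; beyond the scatter). The earlier compounds shown here both carry hydrogen at this carbon, so they showed nothing about what a group placed here does. The result for compound 2 is only a limit of the assay, so the step has a lower bound and no fixed size: the limit of > 64000 nM in this assay, at which 1 of the 3 values shown sits.

The compounds shown leave open whether the lower number follows from the amine itself or from the added carbon, which a methyl or hydroxymethyl group on the same ring carbon would separate. They also leave open how a longer aminoethyl chain would read here, and whether aminomethyl would act alike on the core of compound 1.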